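This account rests on a few compounds, and the source may have more. Where it says the series, first, only, none or still open, it means among the compounds named here.

In an ADME assay on RAW264.7 cells (Mus musculus) for cytotoxicity, read by MTT assay, with a stated time of 24 h (a lower number here means a stronger inhibitor, a higher number a weaker inhibitor), compound 1 `CC(=O)OCC#Cc1cnc2cc(Cl)ccc2n1` gives 20200 nM. Compound 2 `CC(=O)OCC#Cc1cnc2cc([N+](=O)[O-])ccc2n1` carries nitro in place of chloro on an aromatic carbon; in this assay compound 2 gives 13200 nM, a step of a 1.5-fold lower number from compound 1 to compound 2 (0.18 log units; within the scatter). Compound 3 `O=C(OCC#Cc1cnc2cc(Cl)ccc2n1)c1cccs1` differs from compound 1 by thiophen-2-yl in place of methyl on a carbonyl carbon; in this assay compound 3 gives 11300 nM, a step of a 1.8-fold lower number from compound 1 to compound 3 (0.25 log units; within the scatter). Compound 4 `O=C(OCC#Cc1cnc2cc([N+](=O)[O-])ccc2n1)c1cccs1` is not yet measured in this assay. It differs from compound 3 by nitro in place of chloro on an aromatic carbon, the same change as that from compound 1 to compound 2, made on the core of compound 3 rather than that of compound 1. Compound 4 is expected to show a step of a 1.4-fold lower number from compound 3 to compound 4 (0.15 log units; within the scatter) because the same change gave a 1.5-fold lower number from compound 1 to compound 2 (0.18 log units; within the scatter). The value of compound 4 in this assay is estimated at 8000 nM, expected to lie between 4000 nM and 16000 nM.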

Compound 4, half-maximal inhibitory concentration: 19900 nM
Compound 4: the middle estimate sits 2.5-fold (0.40 log units) below what was measured, outside the stated range (above it).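

In this assay nitro in place of chloro on an aromatic carbon now gives a 1.8-fold higher number from compound 3 to compound 4 (0.25 log units; within the scatter) and so does not carry over from one core to the other: the same change on two cores in this assay, a 1.5-fold lower number (0.18 log units; within the scatter) from compound 1 to compound 2 and a 1.8-fold higher number (0.25 log units; within the scatter) from compound 3 to compound 4, 2.7-fold (0.43 log units) apart, beyond the scatter of two such steps. Thiophen-2-yl in place of methyl on a carbonyl carbon gives a 1.5-fold higher number from compound 2 to compound 4 (0.18 log units; within the scatter) and likewise does not carry over: the same change on two cores in this assay, a 1.8-fold lower number (0.25 log units; within the scatter) from compound 1 to compound 3 and a 1.5-fold higher number (0.18 log units; within the scatter) from compound 2 to compound 4, 2.7-fold (0.43 log units) apart, beyond the scatter of two such steps. Within the data shown here, each single step lies within the scatter, so these four compounds show only that the two changes do not simply add up on this pair of cores, not why they fail to do so or whether the same would hold on any other core.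

The compounds shown leave open how an amine or a nitrile on the aromatic carbon would behave. The same question stands for a phenyl group or a longer alkyl chain on the carbonyl carbon.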